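Lengthening an Alkoxy Chain by One Carbon

This account rests on a few compounds, and the source may have more. Where it says the series, first, only, none or still open, it means among the compounds named here.

Three compounds have been measured in a functional assay on A2780 cells (Homo sapiens) for antiproliferative activity, read by MTT assay, with a stated time of 3 days; a lower number here means a stronger inhibitor, a higher number a weaker inhibitor:
Compound 1, `CCCCOC1(c2ccc(Br)cc2)SC=C(C)n2c1noc2=O`, gives 82000 nM.
Compound 2, `CCCCCCCCCCCCCCCCCCOC1(c2ccc(Br)cc2)SC=C(C)n2c1noc2=O`, gives only > 100000 nM, which is a limit of the assay and not a number (the limit of > 100000 nM in this assay, at which 1 of the 3 values shown sits).
Compound 3, `CC/C=C\COC1(c2ccc(Cl)cc2)SC=C(C)n2c1noc2=O`, gives 55000 nM.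

The numbers of compound 1 and compound 3 lie within the usual scatter of each other, so neither can be called the stronger; compound 2 reaches only the limit. Compound 4, `CCCCCOC1(c2ccc(Br)cc2)SC=C(C)n2c1noc2=O`, has not yet been measured. It differs from compound 1 by methyl in place of hydrogen on a saturated chain carbon, four bonds along the chain from an oxygen on a saturated carbon. Among the measured compounds shown here, no measured step of this kind is available, so the change is expected to shift the number in this assay little, if at all, beyond the scatter. For compound 4 the expected value is 80000 nM, within the range 40000 nM to 160000 nM. This amounts to an expected step of a 1.0-fold lower number from compound 1 to compound 4 (0.01 log units; within the scatter).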

Compound 4, half-maximal inhibitory concentration: 108000 nM
Compound 4: the middle estimate sits 1.4-fold (0.13 log units) below what was measured; the measured number falls inside the stated range.
By their numbers in this assay, from the lowest: compounds 3, 1 and 4 (each within the scatter of the next).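

Methyl in place of hydrogen on a saturated chain carbon, four bonds along the chain from an oxygen on a saturated carbon, gives a 1.3-fold higher number from compound 1 to compound 4 (0.12 log units; within the scatter). Among the compounds shown here, this is the first measured step at this position, and in this assay it shows that one more carbon on this chain makes no readable difference. Both compounds give weak numbers, so the top of the readable range is close: the limit of > 100000 nM in this assay, at which 1 of the 4 values shown sits.

From the compounds shown here alone, whether an amine or a carboxylic acid on this chain would give a clearly lower number stays open. So does the effect of an octyl chain in this place.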